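This account rests on a few compounds, and the source may have more. Where it says the series, first, only, none or still open, it means among the compounds named here.

In a functional assay on HT-29 cells (Homo sapiens) for antiproliferative activity, read by sulforhodamine B assay, with a stated time of 48 h (on this read-out higher numbers stand for weaker inhibition and lower numbers for stronger inhibition), compound 1 `COc1ccccc1OS(=O)(=O)c1ccc(N2CCN(C)C2=O)cc1` gives 26000 nM, while compound 2 `COc1cccc(OS(=O)(=O)c2ccc(N3CCN(C)C3=O)cc2)c1` gives 2500 nM, the lower of the two numbers. Compound 3 `Cc1ccc(OS(=O)(=O)c2ccc(N3CCN(C)C3=O)cc2)cc1` has not been measured. It carries 4-methylphenyl in place of 3-methoxyphenyl on an oxygen. For the measured compounds named here, the only measured step at this place is a 10-fold lower number from compound 1 to compound 2 (1.02 log units; beyond the scatter), which shows that a change there can be large. That step involves no 4-methylphenyl group, so it gives no clear direction for the new change. The expected result is therefore a 1.4-fold lower number from compound 2 to compound 3 (0.14 log units; within the scatter), with no shift beyond the scatter anticipated. The estimated value for compound 3 is 1800 nM, with an expected range of 400 nM to 8000 nM.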

Compound 3, half-maximal inhibitory concentration: > 100000 nM
Compound 3: no number, only a limit (the forecaster's own chance of this, stated with the estimate: 5%); middle value at least 55-fold (1.74 log units) away from the limit.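

Compound 3 gives only a limit of the assay, not a number: the limit of > 100000 nM in this assay, at which 1 of the 3 values shown sits. The group on this oxygen can therefore decide nearly all of the activity here: 4-methylphenyl in place of 3-methoxyphenyl gives an at least 40-fold higher number from compound 2 to compound 3 (1.60 log units; beyond the scatter), and in place of 2-methoxyphenyl it gives an at least 3.8-fold higher number from compound 1 to compound 3 (0.58 log units; beyond the scatter). Of these three compounds, compound 2, with 3-methoxyphenyl, has the lowest number.

This change swaps methoxy for methyl and also moves the group, and the compounds shown cannot separate those two effects. Going by these compounds, the results for 3-methylphenyl and 4-methoxyphenyl remain open, as does that of an amine on this ring.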